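A Second Chloro on the Aryl Ring of Compound 2

The source may hold more compounds than are shown below. What is called first, only, known or untested is meant among the compounds shown, and "the series" means these compounds.

compound 1 `O=C1CSC(c2cccc(F)c2)N1CCN1CCCCC1` — 84%
compound 2 `O=C1CSC(c2ccccc2Cl)N1CCN1CCCCC1` — 71%

Of the compounds shown here, two have been measured in an ADME assay on Vero cells (Chlorocebus sabaeus) for cytotoxicity, read by neutral red uptake, tested at 197 ug/mL; on this read-out lower numbers stand for a stronger effect and higher numbers for a weaker effect at the one concentration tested. Compound 1 `O=C1CSC(c2cccc(F)c2)N1CCN1CCCCC1` gives 84%, and compound 2 `O=C1CSC(c2ccccc2Cl)N1CCN1CCCCC1` gives 71%. Compound 2 stands lowest of the two numbers; its nearest neighbour is compound 1, and the step of a number 13 percentage points lower from compound 1 to compound 2 (beyond the scatter) separates them, a modest change that came with 2-chlorophenyl in place of 3-fluorophenyl on a saturated ring carbon.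

Compound 3 `O=C1CSC(c2c(Cl)cccc2Cl)N1CCN1CCCCC1` has not yet been measured in this assay. It differs from compound 2 in one place: chloro in place of hydrogen on an aromatic carbon. The entering chloro sits ortho to a large group and meta to a chloro group. Among the compounds with values here, only one measured step exists, and it concerns a different change of the aryl ring, so it bears on the present step only loosely; it showed that a change on this ring can move the read-out by a modest amount. For compound 3 a small further step downward is therefore expected, a number 9 percentage points lower from compound 2 to compound 3 (within the scatter), though a step within the scatter would not surprise. Compound 3 is thus estimated at 62%, within 40% to 85%.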

Compound 3, a percentage reported as activity, at one concentration (the size of the read-out at that concentration, not a potency): 75%
The estimate for compound 3 lay 13 percentage points below the measured number; the range from low to high includes it.
By their numbers in this assay, from the lowest: compounds 2, 3 and 1 (each within the scatter of the next, the first and the last beyond it).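

On this aromatic carbon, ortho to a large group and meta to a chloro group, chloro in place of hydrogen gave a number 4 percentage points higher from compound 2 to compound 3 (within the scatter) in this assay, so the second chloro left no change that can be told from the scatter. The earlier step, a number 13 percentage points lower from compound 1 to compound 2 (beyond the scatter), had shown that a change on this aryl ring can move the read-out beyond the scatter; this result shows that a change on the ring need not do so, and that this position accepts chloro without a detectable shift at the one concentration tested. No measurement shown bears on the reason for this result.

The compounds shown leave open whether a different group at this same position, such as methyl, methoxy or trifluoromethyl, would also leave the read-out within the scatter of compound 2, or whether chloro is a special case. They also leave open whether an amine or a carboxylic acid on this ring would shift the number beyond the scatter, and whether the piperidine-bearing ethyl chain of the shared core has any bearing on the read-out.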